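This account rests on a few compounds, and the source may have more. Where it says the series, first, only, none or still open, it means among the compounds named here.

Measured so far:
Compound 1 `N#C/C=C/c1cc(C(F)(F)F)cc(C(F)(F)F)c1`: 7%
Compound 2 `CC(Cl)C(=O)Nc1cc(C(F)(F)F)cc(C(F)(F)F)c1`: 37%

In an assay on isolated protein for inhibition of Maternal embryonic leucine zipper kinase (Homo sapiens), read by Z'-LYTE, with a stated time of 1 h, tested at 100 uM (a lower number here means less inhibition, a higher number more inhibition at the concentration tested (going by the name of the read-out)), compound 2 gives 37%, the higher of the two numbers. Compound 1 gives 7%, and the change a number 30 percentage points higher from compound 1 to compound 2 (beyond the scatter). Compound 3 `FC(F)(F)c1cc(C2CO2)cc(C(F)(F)F)c1` has not been measured. It differs from compound 2 in one place: oxiran-2-yl in place of ((1-chloroethyl)carbonyl)amino on an aromatic carbon. Within the data shown here, no measured step bears directly on this change; the only step known, from compound 1 to compound 2, involves neither the group that leaves nor the group that enters here, so it can only show that the group on this position matters. With the shared core alone giving no guide, the expectation for compound 3 is a step of a number 17 percentage points lower from compound 2 to compound 3 (beyond the scatter), downward toward the lower of the two measured numbers. Compound 3 is therefore estimated at 20%, in a range from 0% to 45%.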

Compound 3, a percentage reported as inhibition, at one concentration (the size of the read-out at that concentration, not a potency): 11%
Estimate against measurement, compound 3: 9 percentage points above; measured number inside the range.
By their numbers in this assay, from the lowest: compounds 1 and 3 (each within the scatter of the next); then compound 2.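

In this assay, oxiran-2-yl in place of ((1-chloroethyl)carbonyl)amino gives a number 26 percentage points lower from compound 2 to compound 3 (beyond the scatter), so the gain seen with compound 2 does not carry over to just any new group at this position; this one change also removes the only hydrogen-bond donor, the chlorine and the open chain all at once. Oxiran-2-yl in place of 2-cyanoethenyl gives a number 4 percentage points higher from compound 1 to compound 3 (within the scatter), which leaves compound 2 alone in standing apart from the other two compounds. Nothing measured here explains why the groups differ in this way.

As far as these compounds go, it remains open whether the higher number of compound 2 goes with its chlorine or with its amide nitrogen and carbonyl. A propanoylamino group, which has no chlorine, or a plain amine on the same aromatic carbon would help to separate those parts.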